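Moving the carboxylic acid on a cyclopropyl-linked phenyl ring

The compounds below may be only part of what the source reports. "The series", "measured", "known", "first", "only" and "open" are said of these compounds alone.

This account follows a single change between two compounds that share a common core. Compound 1 `O=C(O)c1cccc(C2CC2c2ccc(OCc3c(-c4c(Cl)cccc4Cl)noc3C3CC3)cc2Cl)c1` is the higher of the two measured compounds in an ADME assay on the whole organism (strain C57BL/6J) for pharmacokinetics, with Mus musculus as the target, at a dose of 5 mg/kg by the oral route; a higher number here means that a larger share of the oral dose reaches the circulation, a lower number that a smaller share of the oral dose reaches the circulation: in this assay compound 1 gives 53%, whereas compound 2 `CC(C)n1nc(C(=O)O)cc1[C@H]1C[C@](O)(c2ccc(OCc3c(-c4c(Cl)cccc4Cl)noc3C3CC3)cc2Cl)C1` gives 18%, a gap that lies beyond the scatter. Compound 3 `O=C(O)c1ccc(C2CC2c2ccc(OCc3c(-c4c(Cl)cccc4Cl)noc3C3CC3)cc2Cl)cc1` has not yet been measured. It differs from compound 1 only in one place, (4-carboxyphenyl in place of 3-carboxyphenyl on a saturated ring carbon); the whole rest of the molecule is unchanged. Going by the values given here, no measured pair shows what such a change does here. Because compound 1 reaches 53% and the two compounds are built from the same atoms, the step from compound 1 to compound 3 is expected to be small, most likely within the scatter, as a number 8 percentage points lower from compound 1 to compound 3 (within the scatter). Compound 3 is therefore estimated at 45%, with a plausible range from 20% to 70%.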

Compound 3, oral bioavailability in the Mus musculus assay: 44%
For compound 3 the middle estimate is 1 percentage points above the measured one; the range from low to high includes it.
By their numbers in the Mus musculus assay, from the lowest: compound 2; then compounds 3 and 1 (each within the scatter of the next).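

Until now, no pair of compounds had shown what the position of the carboxylic acid on this phenyl ring does. In the Mus musculus assay, the pair gives a number 9 percentage points lower from compound 1 to compound 3 (within the scatter), so at this place on a saturated ring carbon of the three-membered ring, the two arrangements cannot be told apart by oral bioavailability. In a physicochemical assay for solubility (a higher number here means a more soluble compound, a lower number a less soluble compound), compound 1 gives 20000 nM and compound 3 gives 72000 nM, so the same exchange of 3-carboxyphenyl for 4-carboxyphenyl does separate the two compounds in solubility: the measured solubility of compound 1, 20000 nM, and of compound 3, 72000 nM, a 3.6-fold higher number (0.56 log units; beyond the scatter)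

This single pair sets no general rule for the shared core. The compounds shown leave open how either read-out would respond if a tetrazole or a primary amide stood on the phenyl ring in place of the carboxylic acid.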